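Methyl Added Beside the Carboxylic Acid in Two Cores

The source may report more compounds than this note shows. Statements on the series, on what has been measured and on what is new or still open speak of the compounds shown alone.

Of the compounds shown here, three have been measured in a physicochemical assay for lipophilicity, at pH 7.4; a lower number here means a more polar compound, a higher number a more lipophilic compound. Compound 1 `CC(C(=O)O)c1nn(Cc2cn3cc(OCC4CC4)c(Cl)cc3n2)c2ccccc2c1=O` gives 2.44 in this assay. Compound 3 `CC(C)(C(=O)O)c1nn(Cc2cn3cc(OCC4CC4)c(Cl)cc3n2)c2ccccc2c1=O` differs from it by methyl in place of hydrogen on a saturated chain carbon bound to an aromatic carbon, a carbonyl carbon and a saturated chain carbon, and in this assay compound 3 gives 2.95; the step is a number 0.51 log units higher from compound 1 to compound 3 (beyond the scatter). Compound 2 `O=C(O)Cn1nc(Cn2cc3cc(OCC4CC4)c(Cl)cc3n2)c2ccccc2c1=O` carries a different core, and the difference between the two cores is not broken down here. In this assay compound 2 gives 2.79, a value that lies within the scatter of compound 3 and beyond the scatter of compound 1.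

Compound 4 `C[C@H](C(=O)O)n1nc(Cn2cc3cc(OCC4CC4)c(Cl)cc3n2)c2ccccc2c1=O` has not yet been measured. It differs from compound 2 by methyl in place of hydrogen on a saturated chain carbon bound to an aromatic nitrogen and a carbonyl carbon. This is the same kind of change as that from compound 1 to compound 3, but the place differs: in compound 2 the carbon is bound to an aromatic nitrogen and a carbonyl carbon, in compound 1 to an aromatic carbon, a carbonyl carbon and a saturated chain carbon. The step to compound 4 is expected to be a number 0.41 log units higher from compound 2 to compound 4 (beyond the scatter) in this assay, resting on the step of a number 0.51 log units higher from compound 1 to compound 3 (beyond the scatter) seen with compound 1. Compound 4 is therefore expected to give 3.2 in this assay, between 2.9 and 3.5.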

Compound 4, distribution coefficient: 2.99
Compound 4: the middle estimate sits 0.21 log units above what was measured; the measured number falls inside the stated range.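

In this assay, the step in the core of compound 2 is a number 0.20 log units higher from compound 2 to compound 4 (within the scatter) and so gives no clear change, while the same kind of change in the core of compound 1 was a number 0.51 log units higher from compound 1 to compound 3 (beyond the scatter) in the same assay. Among these compounds, a step beyond the scatter in one core therefore did not reappear as a step beyond the scatter in the other, but with only one pair in each core and the methyl entering at carbons with different neighbours, the result cannot separate the role of the core from that of the place, nor does it show how the change would behave in further cores. Nothing at hand bears on the reason for the difference between the two results. The compounds shown leave open how an ethyl group would read in place of the methyl on either core. They also leave open whether a primary amide in place of the carboxylic acid would alter the step.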